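Imidazole in place of lactam on the shared core

The compounds below may be only part of what the source reports. "The series", "measured", "known", "first", "only" and "open" are said of these compounds alone.

Measured compounds:
compound 1, `CC(C)C(c1ccc(-c2ccc3cccc(F)c3c2)[nH]c1=O)N1CCCCC1=O`, 0.0967 h
compound 2, `CCn1ncc2c(F)cc(-c3ccc(C(CC)(CC)c4nnc[nH]4)c(=O)[nH]3)cc21`, > 3 h
compound 3, `CC(C)C(c1cnc(N)s1)c1ccc(-c2ccc3cccc(F)c3c2)[nH]c1=O`, 0.08 h

In an ADME assay on microsomes from liver (Mus musculus) for metabolic stability (a higher number here means that the compound lasts longer, a lower number that the compound disappears faster), compound 1 gives 0.0967 h. Compound 3 gives 0.08 h, and the step of a 1.2-fold lower number from compound 1 to compound 3 (0.08 log units; within the scatter) means the two numbers sit within the scatter of each other, so compound 1 cannot be placed above or below compound 3. For compound 2 the assay reports only a limit, (the limit of > 3 h in this assay, at which 1 of the 3 values shown sits), not a number.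

Compound 4 is `Cc1c[nH]c(C(c2ccc(-c3ccc4cccc(F)c4c3)[nH]c2=O)C(C)C)n1`. It differs from compound 1 as follows: 4-methyl-1H-imidazol-2-yl in place of 2-oxopiperidin-1-yl on a saturated chain carbon bound to an aromatic carbon and a saturated chain carbon. Going by the values given here, the one measured step that resembles this change is a 1.2-fold lower number from compound 1 to compound 3 (0.08 log units; within the scatter), in which a small aromatic heterocycle bearing nitrogen also took the place of the 2-oxopiperidin-1-yl group and the number stayed within the scatter. On that basis compound 4 is expected to show no step beyond the scatter, a 1.0-fold higher number from compound 1 to compound 4 (0.01 log units; within the scatter). The estimate for compound 4 in this assay is 0.1 h, with a range from 0.04 h to 0.3 h.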

Compound 4, half-life: < 0.0667 h
Compound 4: a limit, no number; the forecaster's own chance of this, stated with the estimate: 2%; middle value at least 1.4-fold (0.17 log units) away from the limit.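

Compound 4 gives a limit and not a number: the limit of < 0.0667 h in this assay, at which 1 of the 4 values shown sits.

In this assay the two new steps are an at least 1.4-fold lower number from compound 1 to compound 4 (0.16 log units; that floor lies within the scatter) and an at least 1.1-fold lower number from compound 3 to compound 4 (0.07 log units; that floor lies within the scatter), so neither floor separates the 4-methyl-1H-imidazol-2-yl group from the 2-oxopiperidin-1-yl or the 2-amino-1,3-thiazol-5-yl group. Going by these compounds alone, what the earlier compounds did not show is that a third group on this saturated chain carbon, here a five-membered aromatic ring with 2 hetero atoms and a hydrogen-bond donor, also brings no step to a higher number.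

Going by these compounds, the true size of both steps stays open, as each is known only as a floor. Also open, on these data alone, is whether a carboxylic acid or a simple amine on this saturated chain carbon would give a step beyond the scatter.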